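Working notes: pentylsulfanyl to methylsulfanyl on compound 3

A few compounds are considered here, and "the series" means these few. Any claim that something is new, unique, unknown or untested is made for them only; others in the source may bear on it.

Measured compounds:
compound 1 `COc1ccc(CNc2nc([SeH])nc3ccccc23)cc1`: 94000 nM in a functional assay on MCF7 cells (Homo sapiens) for cytotoxicity, read by MTT assay, with a stated time of 72 h; on this read-out lower numbers stand for stronger inhibition of growth and higher numbers for weaker inhibition of growth
compound 2 `[SeH]c1nc(NCc2ccccc2)c2cccnc2n1`: only the limit > 100000 nM in this assay, not a number
compound 3 `CCCCCSc1nc(NCc2ccc([Se]C)cc2)c2ccccc2n1`: 75200 nM in this assay

Two numbers and one limit make up the set. Compound 3 and compound 1 fall within the scatter of each other, so neither can be told apart from the other on these data. The limit for compound 2 is noted at the limit of > 100000 nM in this assay, at which 1 of the 3 values shown sits, and carries no number.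

Compound 4 `CSc1nc(NCc2ccc([Se]C)cc2)c2ccccc2n1` is not yet measured. Relative to compound 3 the change is hydrogen in place of butyl on a saturated chain carbon bound to a sulfur, reading pentylsulfanyl to methylsulfanyl one bond further out. Within the data shown here, no step between measured compounds covers such a change, and nothing in the set ties chain length on sulfur to growth inhibition. The expected step from compound 3 to compound 4 is therefore small, a 1.2-fold higher number from compound 3 to compound 4 (0.08 log units; within the scatter), with no direction beyond the scatter favoured. For compound 4 the estimate in this assay is 90000 nM, with a range from 40000 nM to 200000 nM.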

Compound 4, concentration for total growth inhibition: > 100000 nM
Compound 4 ended at the assay's limit; the forecaster's own chance of this, stated with the estimate: 35%; at least 1.1-fold (0.04 log units) between middle value and limit.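

Hydrogen in place of butyl gives the only step in the set at this place, on a saturated chain carbon bound to a sulfur: in this assay it reads as an at least 1.3-fold higher number from compound 3 to compound 4 (0.12 log units; that floor lies within the scatter). Losing the butyl brings no measurable gain in growth inhibition, which the earlier compounds could not show, as none of them pair up in one place. The result for compound 4 is a limit and not a number, so the step is only a floor and its true size stays unknown because of where the value sits: the limit of > 100000 nM in this assay, at which 2 of the 4 values shown sit.

Going by these compounds, whether the true step from pentylsulfanyl to methylsulfanyl goes beyond the scatter remains open. Also open, on these data alone, is how a propyl chain, a longer chain such as decyl, or an amine at the end of the chain on sulfur would read in this assay.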